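This account rests on a few compounds, and the source may have more. Where it says the series, first, only, none or still open, it means among the compounds named here.

Measured so far in a physicochemical assay for lipophilicity, at pH 7.4; a higher number here means a more lipophilic compound, a lower number a more polar compound:
- compound 1 `Cc1cc(C)c(CN2CCc3c(Cl)cc([C@H](CO)[C@H]4CCOC4)c(Cl)c3C2=O)c(=O)[nH]1` gives 2
- compound 2 `Cc1cc(C)c(CN2CCc3c(Cl)cc([C@H](CO)[C@@H]4CCCO4)c(Cl)c3C2=O)c(=O)[nH]1` gives 2.4
- compound 3 `CCOC(c1cc(Cl)c2c(c1Cl)C(=O)N(Cc1c(C)cc(C)[nH]c1=O)CC2)C1CS(=O)(=O)C1` gives 2.4; 2.3 (2 entries)

Compound 2 stands higher of the two compounds with a single number, and the several entries of compound 3 in this assay, 2.4; 2.3 (2 entries) offer no single figure to set beside it. The next compound is compound 4 `Cc1cc(C)c(CN2CCc3c(Cl)cc([C@@H](C)CO)c(Cl)c3C2=O)c(=O)[nH]1` and the change is methyl in place of oxolan-2-yl on a saturated chain carbon bound to an aromatic carbon and a saturated chain carbon with methyl in place of oxolan-2-yl on a saturated chain carbon bound to an aromatic carbon and a saturated chain carbon.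

Within the data shown here, only one measured step bears on this place. It is a number 0.40 log units higher from compound 1 to compound 2 (beyond the scatter) and it merely puts oxolan-2-yl in place of oxolan-3-yl, so it gives a modest scale for changes there but does not measure the loss of the ring. On that scale, a small fall is expected in this assay and it may not clear the scatter. The expected change is a number 0.20 log units lower from compound 2 to compound 4 (within the scatter) as an estimate only. Compound 4 is estimated at 2.2 within an expected range of 1.8 to 2.6 in this measurement.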

Compound 4, distribution coefficient: 2.5
Estimate against measurement, compound 4: 0.30 log units below; the range from low to high includes it.
By their numbers in this assay, from the lowest: compound 1; then compounds 2 and 4 (each within the scatter of the next).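

In this assay, methyl in place of oxolan-2-yl on the saturated chain carbon gives a number 0.10 log units higher from compound 2 to compound 4 (within the scatter), so losing the five-membered ring and its hydrogen-bond acceptor leaves no resolved change in the read-out. Oxolan-3-yl is the group that stands apart, as methyl in its place gives a number 0.50 log units higher from compound 1 to compound 4 (beyond the scatter). Among these three compounds, then, which ring sits at this carbon makes a measurable difference, while the presence of a ring as such does not. Nothing in the data at hand accounts for this difference.

The compounds shown leave open whether an ethyl group, a longer chain or an amine at this carbon would fall with compound 2 and compound 4 or with compound 1. They also leave open whether oxolan-3-yl would keep its gap from methyl on a different core.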